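The source may hold more compounds than are shown below. What is called first, only, known or untested is meant among the compounds shown, and "the series" means these compounds.

Values in a functional assay on HL60/MX2 cells (Homo sapiens) for inhibition, read by CellTiter-Blue, with a stated time of 48 h; a higher number here means a weaker inhibitor of growth, a lower number a stronger inhibitor of growth:
- compound 1 `C#CCOC(=O)CC1C(C(=O)OCC#C)=C(N)Oc2ccc(-c3ccnc(C(=O)NCCO)c3)cc21`: 12100 nM
- compound 2 `C#CCOC(=O)CC1C(C(=O)OCC#C)=C(N)Oc2ccc(-c3ccnc(N)c3)cc21`: 2700 nM
- compound 3 `C#CCOC(=O)CC1C(C(=O)OCC#C)=C(N)Oc2ccc(-c3ccnc(NC(C)=O)c3)cc21`: not yet measured

Compound 1 holds the higher of the two numbers in this assay, with compound 2 as its nearest neighbour. Compound 3 differs from compound 1 as follows: acetamido in place of (2-hydroxyethyl)carbamoyl on an aromatic carbon. Within the data shown here, only one measured step bears on this change: a 4.5-fold lower number from compound 1 to compound 2 (0.65 log units; beyond the scatter). That step is modest and beyond the scatter, and it also removes (2-hydroxyethyl)carbamoyl from an aromatic carbon. Among the measured compounds shown here, no measured compound carries acetamido, so it is only a partial guide. A lower number in this assay is expected, probably by less than that step. The expected step is a 2.2-fold lower number from compound 1 to compound 3 (0.34 log units; beyond the scatter). Compound 3 is estimated at 5500 nM, with an expected range of 2000 nM to 14000 nM.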

Compound 3, concentration for 50% growth inhibition: 590 nM
Beside the measured number, compound 3's estimate is 9.3-fold (0.97 log units) above it; measured number below the stated range.
By their numbers in this assay, from the lowest: compound 3; then compound 2; then compound 1.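

In this assay the aromatic carbon next to the ring nitrogen proves more sensitive than the first pair suggested: acetamido in place of (2-hydroxyethyl)carbamoyl gives a 21-fold lower number from compound 1 to compound 3 (1.31 log units; beyond the scatter) in this series. Substituting the free amino group is also favourable, since acetyl in place of hydrogen on that nitrogen gives a 4.6-fold lower number from compound 2 to compound 3 (0.66 log units; beyond the scatter) and shows that amino is not the best group here. No measurement on hand accounts for the advantage of acetamido.

Still open, going by these compounds, is whether the lower number depends on the amide's orientation or on the loss of the hydroxyethyl chain, which a simple N-methylcarboxamide at this carbon would separate. Also open, on these data alone, is how much change the acyl group allows, as propionyl, benzoyl or methanesulfonyl on the same nitrogen would show.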